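Removing a methoxy group from compound 1

The source may hold more compounds than are shown below. What is called first, only, known or untested is meant among the compounds shown, and "the series" means these compounds.

The measured compounds:
Compound 1, `COc1ccc(CNc2nc3cc(N)cc(N)c3nc2-c2ccccc2)cc1OC`, gives 7240 nM in a functional assay on RPMI8266 cells (Homo sapiens) for inhibition, read by sulforhodamine B assay, with a stated time of 48 h; on this read-out lower numbers stand for stronger inhibition of growth and higher numbers for weaker inhibition of growth.
Compound 2, `COc1cc(CNc2nc3cc(N)cc(N)c3nc2-c2ccccc2)cc(OC)c1OC`, gives 3020 nM in this assay.
Compound 3, `CCOC(=O)[C@H](CCC(=O)O)NC(=O)c1ccc(Oc2nc3cc(N)cc(N)c3nc2-c2ccccc2)cc1`, reaches only a limit of the assay, < 100000 nM in this assay, so no number is known for it (the limit of < 100000 nM in this assay, at which 1 of the 3 values shown sits).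

Among the two numbers available, compound 1 stands highest, and compound 2 sits nearest to it. Among the compounds with values here, the one measured step, a 2.4-fold lower number from compound 1 to compound 2 (0.38 log units; beyond the scatter), shows that adding a methoxy group to the aromatic ring that carries the other methoxy groups made the number modestly smaller.

Compound 4, `COc1ccc(CNc2nc3cc(N)cc(N)c3nc2-c2ccccc2)cc1`, differs from compound 1 by hydrogen in place of methoxy on an aromatic carbon. This change runs in the opposite sense to the measured step: a methoxy is taken away rather than added. Since adding one in the step from compound 1 to compound 2 lowered the number, taking one away is expected to raise it somewhat, though the measured step is modest and compound 4 loses a different methoxy than compound 2 gains. The estimate for compound 4 in this assay is therefore 11000 nM, within a range from 4000 nM to 30000 nM, meaning an expected step of a 1.5-fold higher number from compound 1 to compound 4 (0.18 log units; within the scatter).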

Compound 4, concentration for total growth inhibition: 15800 nM
The estimate for compound 4 lay 1.4-fold (0.16 log units) below the measured number; low and high end bracket the measured number.
By their numbers in this assay, from the lowest: compound 2; then compound 1; then compound 4.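

Taking this methoxy group away turns 3,4-dimethoxyphenyl into 4-methoxyphenyl and gives a 2.2-fold higher number from compound 1 to compound 4 (0.34 log units; beyond the scatter) in this assay. The earlier compounds shown here showed only the effect of adding a methoxy group to the ring, whereas this result shows that the methoxy group at this place, ortho to another methoxy group, also counts: with hydrogen there, inhibition of growth is weaker. Both steps from compound 1 now agree, with one methoxy group fewer raising the number and one more lowering it, and both steps are modest.

The measurements shown give no reason for this effect of the methoxy group. On these data alone, whether a hydroxyl group, a chlorine atom or an amine at this place would keep the number of compound 1 or move it further remains open.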